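Methyl on the ring in two thiosemicarbazone pairs

This account rests on a few compounds, and the source may have more. Where it says the series, first, only, none or still open, it means among the compounds named here.

Compound 1 `N/C(=N\NC(=S)N1CCCCCC1)c1ccccn1` and compound 2 `N/C(=N\NC(=S)N1CCCCC1)c1ccccn1` share most of their structure; how their two cores differ is not broken down here. In a functional assay on A-375 cells (Homo sapiens) for cytotoxicity, read by MTT assay, with a stated time of 72 h, tested at 30 uM (on this read-out lower numbers stand for less inhibition of growth and higher numbers for more inhibition of growth at the one concentration tested), compound 1 gives 90% and compound 2 gives 87%, a difference within the scatter. Compound 3 `Cc1cccc(/C(N)=N/NC(=S)N2CCCCC2)n1` differs from compound 2 by methyl in place of hydrogen on an aromatic carbon; in this assay compound 3 gives 80.9%, and the step is a number 6.1 percentage points lower from compound 2 to compound 3 (within the scatter). Compound 4 `Cc1cccc(/C(N)=N/NC(=S)N2CCCCCC2)n1` carries the same change on compound 1, namely (methyl in place of hydrogen on an aromatic carbon). Because the earlier step was a number 6.1 percentage points lower from compound 2 to compound 3 (within the scatter), compound 4 is expected to sit close to compound 1 in this assay, with an estimated step of a number 5 percentage points lower from compound 1 to compound 4 (within the scatter). Compound 4 is thus estimated at 85%, expected between 75% and 93%.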

Compound 4, percent growth inhibition at one concentration: 70.3%
The estimate for compound 4 lay 14.7 percentage points above the measured number, and the stated range ends above it.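

In this assay, putting methyl in place of hydrogen on an aromatic carbon of the core of compound 1 gives a number 19.7 percentage points lower from compound 1 to compound 4 (beyond the scatter). Set beside the same change on the other core, the two steps cannot be told apart: the same change on two cores in this assay, a number 6.1 percentage points lower (within the scatter) from compound 2 to compound 3 and a number 19.7 percentage points lower (beyond the scatter) from compound 1 to compound 4, 13.6 percentage points apart, within the scatter of two such steps This gives no sign that the core alters what the methyl does, yet only one of the two steps lies beyond the scatter, and two pairs can neither prove that the change carries over unchanged nor fix its size.

Still open, on these data alone, is whether a different group in the same place, such as ethyl, methoxy or chlorine, would follow the methyl on both cores.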